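The source may hold more compounds than are shown below. What is called first, only, known or untested is meant among the compounds shown, and "the series" means these compounds.

The measured compounds, all sharing one core:

compound 1 `O=C(/C=C/c1ccc2c(c1)B(O)OC2)c1cccs1`, which in a functional assay on HCT-116 cells (Homo sapiens) for cytotoxicity, read by MTT assay, with a stated time of 48 h (a higher number here means a weaker inhibitor, a lower number a stronger inhibitor), gives 14200 nM;
compound 2 `Cc1cccc(C(=O)/C=C/c2ccc3c(c2)B(O)OC3)c1`, which in this assay gives 6700 nM;
compound 3 `Cc1ccc(C(=O)/C=C/c2ccc3c(c2)B(O)OC3)cc1C`, which in this assay gives 6100 nM.

Among these three numbers compound 2 stands second highest. Its nearest neighbour is compound 3, with a gap that falls within the scatter, and its furthest is compound 1, which sits beyond the scatter. The step from compound 1 to compound 2, exchanging the ring on the carbonyl carbon, was modest: a 2.1-fold lower number from compound 1 to compound 2 (0.33 log units; beyond the scatter). The step that adds a methyl on an aromatic carbon of that ring, a 1.1-fold lower number from compound 2 to compound 3 (0.04 log units; within the scatter), stayed within the scatter.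

Compound 4 `COCOc1cccc(C(=O)/C=C/c2ccc3c(c2)B(O)OC3)c1` differs from compound 2 in one place: methoxymethoxy in place of methyl on an aromatic carbon. For the measured compounds named here, no measured step swaps a methyl for a methoxymethoxy, so the closest guide is the change on the same ring from compound 2 to compound 3, which moved the number hardly at all. For that reason no step beyond the scatter is expected in this assay, in either direction. Compound 4 is therefore estimated at 6500 nM, with a range from 2500 nM to 16000 nM, meaning an expected step of a 1.0-fold lower number from compound 2 to compound 4 (0.01 log units; within the scatter).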

Compound 4, half-maximal inhibitory concentration: 13300 nM
For compound 4 the middle estimate is 2.0-fold (0.31 log units) below the measured one, within the range that was stated.
By their numbers in this assay, from the lowest: compounds 3, 2, 4 and 1 (each within the scatter of the next, the first and the last beyond it).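

At this position, on an aromatic carbon meta to a large group, exchanging methyl for methoxymethoxy gives a 2.0-fold higher number from compound 2 to compound 4 (0.30 log units; within the scatter) in this assay, so the two compounds cannot be told apart in this cell test. The earlier compounds shown here showed only what happens when a single methyl is added to this ring, whereas this change replaces 1 heavy atom with 4 and brings in 2 hydrogen-bond acceptors, and even so the step does not rise above the ordinary noise of the measurement. No measurement is available that would explain this result, such as one of how the compounds behave inside the cell or of what they act on.

Going by these compounds, what remains open is how this position would respond to a hydroxyl, an amine, a carboxylic acid or a longer ether chain, any of which would show whether the result holds for groups unlike methyl and methoxymethoxy. With only these two groups compared here at this position, a single step within the scatter cannot show how much larger a group could become before the number truly moves.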